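Carboxy in Place of Dimethylamino: An Expected Step

The compounds below may be only part of what the source reports. "The series", "measured", "known", "first", "only" and "open" are said of these compounds alone.

Three compounds share one core and differ only in the group para to a large group on a six-membered aromatic ring of carbon only. Compound 1 `O=C(O)CCC/C=C\C[C@H]1[C@@H]2CCC(C2)[C@@H]1NS(=O)(=O)c1ccc([N+](=O)[O-])cc1` carries nitro there; in a functional assay (plasma) for inhibition, with Oryctolagus cuniculus as the target (a lower number here means a stronger inhibitor, a higher number a weaker inhibitor), compound 1 gives 1400 nM. Compound 2 `CCc1ccc(S(=O)(=O)N[C@H]2C3CC[C@H](C3)[C@@H]2C/C=C\CCCC(=O)O)cc1` carries ethyl, and in this assay compound 2 gives 4600 nM. Compound 3 `CN(C)c1ccc(S(=O)(=O)N[C@H]2C3CC[C@H](C3)[C@@H]2C/C=C\CCCC(=O)O)cc1` carries dimethylamino; in this assay compound 3 gives 7100 nM, the highest of the three numbers. The steps away from nitro are modest but beyond the scatter, a 3.3-fold higher number from compound 1 to compound 2 (0.52 log units; beyond the scatter) and a 5.1-fold higher number from compound 1 to compound 3 (0.71 log units; beyond the scatter), whereas a 1.5-fold higher number from compound 2 to compound 3 (0.19 log units; within the scatter) lies within the scatter.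

Compound 4 `O=C(O)CCC/C=C\C[C@H]1[C@@H]2CCC(C2)[C@@H]1NS(=O)(=O)c1ccc(C(=O)O)cc1` is reached from compound 3 by a change at the same place: carboxy in place of dimethylamino on an aromatic carbon. Among the compounds with values here, no measured step involves a carboxy group, so the measured steps bear on this one only indirectly: they show that exchanging the group at this place shifts the number in this assay by modest amounts. A step of comparable size is therefore expected, most plausibly back toward the number of compound 1, though the direction remains uncertain. For compound 4 the estimated step is a 2.4-fold lower number from compound 3 to compound 4 (0.37 log units; beyond the scatter), and its expected value in this assay is 3000 nM, within a range from 1000 nM to 10000 nM.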

Compound 4, half-maximal inhibitory concentration: 800000 nM
Beside the measured number, compound 4's estimate is 270-fold (2.43 log units) below it, outside the stated range (above it).
By their numbers in this assay, from the lowest: compound 1; then compounds 2 and 3 (each within the scatter of the next); then compound 4.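

Until now, exchanging the group on this aromatic carbon, para to a large group, had moved the number only modestly, and that could have suggested a position tolerant of change. Carboxy shows otherwise in this assay: the step is large from each of the other three groups, whether dimethylamino (a 110-fold higher number from compound 3 to compound 4 (2.05 log units; beyond the scatter)), ethyl (a 170-fold higher number from compound 2 to compound 4 (2.24 log units; beyond the scatter)) or nitro (a 570-fold higher number from compound 1 to compound 4 (2.76 log units; beyond the scatter)), so compound 4 stands well apart as the weakest inhibitor of the four and the three earlier compounds form a close group by comparison. Dimethylamino and carboxy have the same count of heavy atoms, so that count alone does not separate compound 4 from compound 3, and no measurement given here accounts for the size of the step.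

The compounds shown leave open whether a methyl ester or a primary amide in place of the carboxy group would stay near compound 4 or return to the range of compounds 1, 2 and 3. They also leave open whether a carboxymethyl group, with its acid on a longer chain, would carry the same large penalty.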